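Extending the sulfonamide substituent in a pyrimidine kinase series

A few compounds are considered here, and "the series" means these few. Any claim that something is new, unique, unknown or untested is made for them only; others in the source may bear on it.

Measured compounds:
Compound 1 `CCC1C(=O)N(C)c2cnc(Nc3ccc(S(=O)(=O)NC)cc3)nc2N1c1ccn(C)n1` gives 71.6 nM in an assay for inhibition of serine/threonine-protein kinase PLK2 (Homo sapiens), read by FRET and Z'-LYTE, with a stated time of 1 h; on this read-out higher numbers stand for weaker inhibition and lower numbers for stronger inhibition.
Compound 2 `CC[C@@H]1C(=O)N(C)c2cnc(Nc3ccc(S(=O)(=O)NC)cc3)nc2N1C1CCCC1` gives 3.4 nM in this assay.
Compound 3 `CCCNS(=O)(=O)c1ccc(Nc2ncc3c(n2)N(c2ccn(C)n2)C(CC)C(=O)N3C)cc1` gives 190 nM in this assay.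

Compound 2 stands lowest of the three numbers in this assay, and its gaps to compound 1 and compound 3 both lie beyond the scatter. Compound 4 `CC[C@@H]1C(=O)N(C)c2cnc(Nc3ccc(S(=O)(=O)NCCO)cc3)nc2N1C1CCCC1` differs from compound 2 by hydroxymethyl in place of hydrogen on a saturated chain carbon bound to a sulfonamide nitrogen, so the sulfonamide substituent grows from methyl to 2-hydroxyethyl while the rest of the molecule is kept.

Among the measured compounds shown here, the one measured step that touches the same carbon is a 2.7-fold higher number from compound 1 to compound 3 (0.42 log units; beyond the scatter), a modest loss when the chain is lengthened by an ethyl. The change here is also a lengthening at that carbon, though it brings a hydroxyl rather than a second carbon, and nothing measured shows how such a hydroxyl behaves in this series. Compound 4 is therefore expected to give a modestly higher number than compound 2, a 2.2-fold higher number from compound 2 to compound 4 (0.34 log units; beyond the scatter), with the step in this assay estimated at 7.5 nM and a range from 3 nM to 20 nM.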

Compound 4, half-maximal inhibitory concentration: 7.86 nM
The estimate for compound 4 lay 1.0-fold (0.02 log units) below the measured number; the measured number falls inside the stated range.
By their numbers in this assay, from the lowest: compound 2; then compound 4; then compound 1; then compound 3.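

In this assay, the sulfonamide substituent grows from methyl to 2-hydroxyethyl with a 2.3-fold higher number from compound 2 to compound 4 (0.36 log units; beyond the scatter), a modest loss that is beyond the scatter. Among the compounds shown here, this is the first reading at this carbon for a hydroxyl-bearing group and on the core of compound 2; the earlier step, a 2.7-fold higher number from compound 1 to compound 3 (0.42 log units; beyond the scatter), came from an ethyl on the core of compound 1, and it was also a modest loss beyond the scatter, so both changes at this carbon move the number the same way. No measurement shown here accounts for the size of either step.

On these data alone, whether the hydroxyl itself contributes to the step, or only the added chain length, remains open, as does how a propyl substituent would read on the core of compound 2. Also open, as far as these compounds go, is how an amine, a carboxylic acid or a longer chain would behave in place of the 2-hydroxyethyl.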